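A few compounds are considered here, and "the series" means these few. Any claim that something is new, unique, unknown or untested is made for them only; others in the source may bear on it.

Compound 1, `O=C(/C=C\c1cccc(O)c1)N1N=C(c2ccncc2)OC1c1c[nH]c2ccccc12`: in an ADME assay on A549 cells (Homo sapiens) for cytotoxicity, read by MTT assay, with a stated time of 48 h (a lower number here means a stronger inhibitor of growth, a higher number a weaker inhibitor of growth), compound 1 gives > 30 ug/mL, which is a limit of the assay and not a number.
Compound 2, `O=C(/C=C\c1ccccc1F)N1N=C(c2ccncc2)OC1c1c[nH]c2ccccc12`: in this assay compound 2 gives > 30 ug/mL, again a limit.
Compound 3, `O=C(/C=C\c1cccc(F)c1)N1N=C(c2ccncc2)OC1c1c[nH]c2ccccc12`: in this assay compound 3 gives > 30 ug/mL, also a limit.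

Compound 3 therefore stands where every measured compound stands, at the limit; all three values shown sit there (the limit of > 30 ug/mL in this assay, at which 3 of the 3 values shown sit). The unmeasured compound is compound 4, `O=C(/C=C\c1ccc(F)cc1)N1N=C(c2ccncc2)OC1c1c[nH]c2ccccc12`. Its change from compound 3 is 4-fluorophenyl in place of 3-fluorophenyl on a double-bonded chain carbon bound to a double-bonded chain carbon. Among the compounds with values here, three measured steps bear on changes of this kind, where only the substituted phenyl ring on the chain is exchanged: a step that the two limits leave unreadable from compound 1 to compound 2, a step that the two limits leave unreadable from compound 1 to compound 3 and a step that the two limits leave unreadable from compound 2 to compound 3. None of them has a readable size, as both ends of each sit at the limit (the limit of > 30 ug/mL in this assay, at which 3 of the 3 values shown sit). So nothing in the measured steps points to a step beyond the scatter in this assay in either direction, and the most likely outcome is that compound 4 also comes back as a limit rather than a number. The expected step is a step that the limit leaves unreadable from compound 3 to compound 4. Compound 4 is estimated at 45 ug/mL, with a range from 15 ug/mL to 150 ug/mL.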

Compound 4, concentration for 50% growth inhibition: > 30 ug/mL
Compound 4: no number, only a limit; the forecaster's own chance of this, stated with the estimate: 85%; the middle value does not contradict the limit.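

In this assay compound 4 gives > 30 ug/mL, which is a limit and not a number. Its steps from compound 1, compound 2 and compound 3 therefore cannot be read: the limit of > 30 ug/mL in this assay, at which 4 of the 4 values shown sit.

With no number among them, the compounds shown leave open whether exchanging the substituted phenyl ring on the chain changes growth inhibition at all, and in which direction.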